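The compounds below may be only part of what the source reports. "The series", "measured", "known", "first", "only" and "open" are said of these compounds alone.

Measured compounds:
compound 1 `CC(C)n1cc(Nc2ncc(C3CC3)c(NCCCNC(=O)C3CCC3)n2)cn1`, 4 nM
compound 2 `O=C(NCCCNc1nc(Nc2cnn(C3CC3)c2)ncc1C1CC1)C1CCC1`, 10 nM
compound 3 `O=C(NCCCNc1nc(Nc2cccc(F)c2)ncc1C1CC1)C1CCC1`, 8 nM

In an assay on isolated protein for inhibition of serine/threonine-protein kinase TBK1 (Homo sapiens) (on this read-out lower numbers stand for stronger inhibition and higher numbers for weaker inhibition), the three numbers sit close together. Compound 3 gives the second highest of the three, but its nearest neighbour is compound 2 (a 1.3-fold lower number from compound 2 to compound 3 (0.10 log units; within the scatter)) and its furthest is compound 1 (a 2.0-fold higher number from compound 1 to compound 3 (0.30 log units; within the scatter)), so no separation within this set is established for compound 3.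

Compound 4 `Cn1ccc(Nc2ncc(C3CC3)c(NCCCNC(=O)C3CCC3)n2)n1` differs from compound 3 in one place: 1-methyl-1H-pyrazol-3-yl in place of 3-fluorophenyl on a nitrogen on an aromatic ring. Among the compounds with values here, the steps that bear on this are the two that also exchange the group on the same nitrogen, a 2.0-fold higher number from compound 1 to compound 3 (0.30 log units; within the scatter) and a 1.3-fold lower number from compound 2 to compound 3 (0.10 log units; within the scatter), both of which swap a substituted pyrazolyl against 3-fluorophenyl and both of which stay within the scatter. The reverse direction, phenyl back to a pyrazolyl, would therefore be expected to be small as well. Within the data shown here, the only step that moves beyond the scatter, a 2.5-fold higher number from compound 1 to compound 2 (0.40 log units; beyond the scatter), concerns the substituent carried on the pyrazole nitrogen; compound 4 carries a methyl there and a 1-methyl-1H-pyrazol-3-yl, for which no measured step exists, so some widening of the range is warranted.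

Compound 4 is expected to give about 12 nM in this assay, between 4 nM and 40 nM, an estimated step of a 1.5-fold higher number from compound 3 to compound 4 (0.18 log units; within the scatter) that stays within the scatter.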

Compound 4, half-maximal inhibitory concentration: > 1000 nM
Compound 4 ended at the assay's limit; the forecaster's own chance of this, stated with the estimate: 2%; middle value at least 83-fold (1.92 log units) from the limit.
By their numbers in this assay, from the lowest: compounds 1, 3 and 2 (each within the scatter of the next, the first and the last beyond it). At a limit, above all of these: compound 4.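

In this assay the reading for compound 4 is a limit of the assay and not a number: the limit of > 1000 nM in this assay, at which 1 of the 4 values shown sits. The earlier exchanges of the group on this nitrogen on an aromatic ring, 3-fluorophenyl against 1-isopropyl-1H-pyrazol-4-yl or 1-cyclopropyl-1H-pyrazol-4-yl, all stayed within the scatter, whereas 1-methyl-1H-pyrazol-3-yl brings a large loss at the same place, with an at least 120-fold higher number from compound 3 to compound 4 (2.09 log units; beyond the scatter), an at least 100-fold higher number from compound 2 to compound 4 (2.00 log units; beyond the scatter) and an at least 250-fold higher number from compound 1 to compound 4 (2.39 log units; beyond the scatter). This place therefore does not accept every aromatic group alike, and carrying a pyrazolyl group does not by itself keep the reading low, as compound 1 and compound 2 alone could suggest.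

The pyrazolyl group of compound 4 differs from those of compound 1 and compound 2 both in where it is joined and in the group on its ring nitrogen, so the compounds shown do not separate these two changes. A 1-methyl-1H-pyrazol-4-yl group or a 1-isopropyl-1H-pyrazol-3-yl group on the same nitrogen would tell which of them carries the loss, and the shown data give no reason for it.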